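The source may hold more compounds than are shown below. What is called first, only, known or untested is meant among the compounds shown, and "the series" means these compounds.

Compound 1 `CCCSc1nc(N/N=C/c2ccccc2F)c2nnn(Cc3ccccc3)c2n1` was examined in a functional assay on MCF7 cells (Homo sapiens) for antiproliferative activity, read by MTT assay, with a stated time of 72 h; on this read-out higher numbers stand for weaker inhibition and lower numbers for stronger inhibition. In this assay compound 1 gives only a limit, > 64000 nM, and not a number. Compound 2 `C#CCSc1nc(N/N=C/c2ccc(N(C)C)cc2)c2nnn(Cc3ccccc3)c2n1` likewise reaches only a limit, > 64000 nM. Compound 3 `C#CCSc1nc(N/N=C/c2cc(OC)c(OC)c(OC)c2)c2nnn(Cc3ccccc3)c2n1` gives a real number, 17000 nM. Going by these compounds, compound 1 thus stands at the limit of > 64000 nM in this assay, at which 2 of the 3 values shown sit, so its true value is unknown beyond that boundary. Compound 4 `CCCSc1nc(N/N=C(\C)c2ccccc2O)c2nnn(Cc3ccccc3)c2n1` has not yet been measured in this assay. It differs from compound 1 by a group of 10 heavy atoms (8 carbon, 1 nitrogen, 1 oxygen; one six-membered aromatic ring of carbon only) in place of a group of 9 heavy atoms (7 carbon, 1 nitrogen, 1 fluorine; one six-membered aromatic ring of carbon only), on a nitrogen on an aromatic ring. Among the measured compounds shown here, no measured pair shows what such a change does here, so the step is expected to stay within the usual scatter, an estimated at least 1.2-fold lower number from compound 1 to compound 4 (0.10 log units; that floor lies within the scatter) in this assay. Compound 4 is accordingly expected to give about 50000 nM, somewhere between 15000 nM and 150000 nM.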

Compound 4, half-maximal inhibitory concentration: 11000 nM
Compound 4: middle estimate off by 4.5-fold (0.66 log units), on the high side; measured number outside the range, below it.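

Setting a group of 10 heavy atoms (8 carbon, 1 nitrogen, 1 oxygen), with 1 hydrogen-bond donor, in place of the fluorine-bearing group of 9 heavy atoms, on a nitrogen on an aromatic ring, gives an at least 5.8-fold lower number from compound 1 to compound 4 (0.76 log units; beyond the scatter) in this assay. This position can therefore shift the read-out beyond the scatter. The size is only a floor, as compound 1 gives a limit and not a number: the limit of > 64000 nM in this assay, at which 2 of the 4 values shown sit.

The compounds shown do not separate the contribution of the oxygen from that of the added carbon. Going by these compounds, how a carboxylic acid or a longer chain in this group would behave also remains open.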